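Pyrrole carbamates: removing the acetyl group

The source may hold more compounds than are shown below. What is called first, only, known or untested is meant among the compounds shown, and "the series" means these compounds.

Measured so far:
compound 1 `O=C(NCCCCCn1ccc2ccccc21)Oc1ccccc1` — 94 nM
compound 2 `CC(=O)c1c(-c2ccccc2)c(-c2ccccc2)n(CCCCCCNC(=O)Oc2ccccc2)c1C` — > 10000 nM

Compound 1 `O=C(NCCCCCn1ccc2ccccc21)Oc1ccccc1` gives 94 nM in an assay on microsomes from brain (strain Sprague-Dawley) for inhibition of Fatty-acid amide hydrolase 1 (Rattus norvegicus), read by fluorescence and HPLC, with stated times of 10 min and 60 min; on this read-out lower numbers stand for stronger inhibition and higher numbers for weaker inhibition. Compound 2 `CC(=O)c1c(-c2ccccc2)c(-c2ccccc2)n(CCCCCCNC(=O)Oc2ccccc2)c1C` stands at the limit of this assay, > 10000 nM, so only a boundary and no number is known for it; this is the limit of > 10000 nM in this assay, at which 1 of the 2 values shown sits. No single-point comparison between compound 1 and compound 2 exists, as the two differ in several places at once.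

Compound 3 `Cc1cc(-c2ccccc2)c(-c2ccccc2)n1CCCCCCNC(=O)Oc1ccccc1` is not yet measured. It differs from compound 2 by hydrogen in place of acetyl on an aromatic carbon. Since compound 2 sits at a limit, the size of the step to compound 3 cannot be anchored; a move toward stronger inhibition is expected, but a modest one. Compound 3 is expected to give 8000 nM, with a range of 1500 nM to 30000 nM. That expectation corresponds to a step of an at least 1.2-fold lower number from compound 2 to compound 3 (0.09 log units; that floor lies within the scatter).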

Compound 3, half-maximal inhibitory concentration: 2600 nM
The estimate for compound 3 lay 3.1-fold (0.49 log units) above the measured number; measured number inside the range.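

In this assay, replacing acetyl with hydrogen on this aromatic carbon of the five-membered ring gives an at least 3.8-fold lower number from compound 2 to compound 3 (0.58 log units; beyond the scatter). Acetyl on this carbon is therefore not needed for a measurable value, since compound 3 gives 2600 nM, which provides a number for this substituted core and shows that this position responds to the change. Compound 2 stands at a limit, not at a number: the limit of > 10000 nM in this assay, at which 1 of the 3 values shown sits.

Compound 1 differs from compound 3 in several places, so their values give no reading on any single change. On these data alone, how a carboxylic acid, an amine or a nitrile on this carbon would compare with hydrogen remains open, as does the contribution of the methyl group and the two phenyl groups.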